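The source may hold more compounds than are shown below. What is called first, only, known or untested is meant among the compounds shown, and "the series" means these compounds.

Compound 2, `Cn1nccc1-c1ccccc1NCC1=NCCN1`, is one of three compounds that share a core carrying an aminomethyl-imidazoline side chain and a five-membered aromatic ring. In a functional assay with Alpha-1B adrenergic receptor (Homo sapiens) as the target, read by calcium flux (on this read-out higher numbers stand for larger maximal responses and lower numbers for smaller maximal responses), compound 2 gives 0%, and compound 3, `CCn1nccc1-c1ccccc1NCC1=NCCN1`, gives 0%. Those two stand level at the digits shown and together at the bottom of the three numbers, while compound 1, `CCCn1ncnc1-c1ccccc1NCC1=NCCN1`, gives 74%, a number far above them and beyond the scatter.

Among the measured compounds shown here, the only single-point step measured so far, no change at the digits printed from compound 2 to compound 3 (within the scatter), concerns the chain on the ring nitrogen and changed nothing in this assay. Compound 4, `Cc1n[nH]c(-c2ccccc2NCC2=NCCN2)n1`, differs from compound 2 elsewhere: 3-methyl-1H-1,2,4-triazol-5-yl in place of 1-methyl-1H-pyrazol-5-yl on an aromatic carbon. For the measured compounds named here, no measured step bears directly on this exchange of one five-membered aromatic ring for another. Going by the values given here, the values do show that compound 1, which also carries a triazole, is active, whereas the two pyrazoles are not, but compound 1 also differs from compound 4 in its nitrogen substituent, so no single step settles the matter.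

He therefore expects a rise, a number 35 percentage points higher from compound 2 to compound 4 (beyond the scatter), with wide uncertainty. His estimate for compound 4 in this assay is 35%, ranging from 0% to 80%.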

Compound 4, largest response reached (reported as maximal response), in percent of the reference or control that the assay uses: 0%
The estimate for compound 4 lay 35 percentage points above the measured number; low and high end bracket the measured number.
By their numbers in this assay, from the lowest: compounds 2, 3 and 4 (each within the scatter of the next); then compound 1.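

Among the compounds shown here, the step of no change at the digits printed from compound 2 to compound 4 (within the scatter) is the first measured exchange of the five-membered aromatic ring itself on the aromatic carbon that carries it, ortho to a group of 7 heavy atoms. In this assay, 3-methyl-1H-1,2,4-triazol-5-yl in place of 1-methyl-1H-pyrazol-5-yl therefore gives no measurable gain, even though the entering ring has three hetero atoms rather than two and brings one hydrogen-bond donor. Compound 4, at 0%, shows that a triazole ring at this position does not by itself go with a maximal response on this read-out, and nothing supplied explains this result.

Compound 1 differs from compound 4 in more than one place, so the compounds shown do not separate the contribution of its ring from that of its substitution, and the source of the response of compound 1 at 74% remains unresolved. They also leave open whether a propyl chain on the pyrazole nitrogen, or an amine in place of the methyl group on the triazole ring, would give a response in this assay.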